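Hydroxyphenyl positional swap on a trisubstituted pyridine series

The source may hold more compounds than are shown below. What is called first, only, known or untested is meant among the compounds shown, and "the series" means these compounds.

Compound 1 `Oc1ccc(-c2cc(-c3cccs3)cc(-c3cccc(O)c3)n2)cc1` is the reference point; in a functional assay on DU-145 cells (Homo sapiens) for cytotoxicity, read by CCK-8 assay (on this read-out lower numbers stand for stronger inhibition and higher numbers for weaker inhibition), compound 1 gives 1890 nM. Compound 2 `Oc1ccc(-c2cc(-c3cccs3)cc(-c3ccc(O)cc3)n2)cc1` carries 4-hydroxyphenyl in place of 3-hydroxyphenyl on an aromatic carbon and in this assay compound 2 gives 2190 nM, so that a 1.2-fold higher number from compound 1 to compound 2 (0.06 log units; within the scatter). The two values are indistinguishable on this read-out.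

Compound 3 `Oc1cccc(-c2cc(-c3ccco3)cc(-c3cccc(O)c3)n2)c1` has a different core; the difference between the core of compound 1 and the core of compound 3 is not broken down here. In this assay compound 3 gives 2150 nM, which sits within the scatter of both compound 1 and compound 2.

Compound 4 `Oc1ccc(-c2cc(-c3ccco3)cc(-c3cccc(O)c3)n2)cc1` is not yet measured. Relative to compound 3 it carries 4-hydroxyphenyl in place of 3-hydroxyphenyl on an aromatic carbon. Going by the values given here, this is the same kind of change as the one from compound 1 to compound 2, but the surroundings differ: there the place was meta to a 4-hydroxyphenyl group and meta to a thiophen-2-yl group, here it is meta to a 3-hydroxyphenyl group and meta to a furan-2-yl group. Because a 1.2-fold higher number from compound 1 to compound 2 (0.06 log units; within the scatter), the expected step for the new pair is a 1.1-fold higher number from compound 3 to compound 4 (0.05 log units; within the scatter), essentially flat. Compound 4 is accordingly estimated at 2400 nM, with an expected range from 1300 nM to 4500 nM.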

Compound 4, half-maximal inhibitory concentration: 2070 nM
Beside the measured number, compound 4's estimate is 1.2-fold (0.06 log units) above it; measured number inside the range.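

In this assay, 4-hydroxyphenyl in place of 3-hydroxyphenyl gives a 1.0-fold lower number from compound 3 to compound 4 (0.02 log units; within the scatter), and set beside the same change on the other core, the two steps do not differ: the same change on two cores in this assay, a 1.2-fold higher number (0.06 log units; within the scatter) from compound 1 to compound 2 and a 1.0-fold lower number (0.02 log units; within the scatter) from compound 3 to compound 4, 1.2-fold (0.08 log units) apart, within the scatter of two such steps

Furan-2-yl in place of thiophen-2-yl gives a 1.1-fold higher number from compound 1 to compound 4 (0.04 log units; within the scatter), so this exchange also yields no readable step. These pairs show that the hydroxyphenyl swap stays within the scatter on both cores, but they do not show that a real effect of the swap carries from one core to another, and two pairs set no rule for further cores in the series.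

Open, on these data alone, is whether any change at these places moves the number beyond the scatter, for example a methoxy group or an amine in place of the hydroxyl. Also open, as far as these compounds go, is what a carboxylic acid or a longer alkyl chain would do in place of furan-2-yl or thiophen-2-yl.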